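This account rests on a few compounds, and the source may have more. Where it says the series, first, only, none or still open, it means among the compounds named here.

Measured compounds:
compound 1 `N#C[Se]c1ccc(NC(=O)Oc2ccc(F)cc2)cc1` — 25000 nM
compound 2 `Cc1ccc(OC(=O)Nc2ccc([Se]C#N)cc2)cc1` — 17300 nM

Both carry the same core and differ only on the aromatic carbon para to the carbamate oxygen. In a functional assay on HTB-54 cells (Homo sapiens) for cytotoxicity, read by MTT assay, with a stated time of 72 h (on this read-out lower numbers stand for stronger inhibition of growth and higher numbers for weaker inhibition of growth), compound 1 gives 25000 nM and compound 2 gives 17300 nM. For the measured compounds named here, the one measured step, a 1.4-fold lower number from compound 1 to compound 2 (0.16 log units; within the scatter), is within the scatter, so on these two numbers compound 2 has the lower value but cannot be set apart from compound 1.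

Compound 3 `N#C[Se]c1ccc(NC(=O)Oc2ccc(Cl)cc2)cc1` is the next member, not yet measured in this assay. Its change from compound 2 is chloro in place of methyl on an aromatic carbon. Going by the values given here, no measured step covers chloro directly; the only step that bears on this position, a 1.4-fold lower number from compound 1 to compound 2 (0.16 log units; within the scatter), shows that exchanging one small group for another there left the number within the scatter. The expectation is therefore no step beyond the scatter in this assay, a step of a 1.0-fold lower number from compound 2 to compound 3 (0.01 log units; within the scatter). Compound 3 is estimated at 17000 nM, with a range from 7000 nM to 40000 nM.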

Compound 3, concentration for 50% growth inhibition: 13800 nM
Compound 3: middle estimate off by 1.2-fold (0.09 log units), on the high side, and the stated range covers the measured number.
By their numbers in this assay, from the lowest: compounds 3, 2 and 1 (each within the scatter of the next).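

With chloro in place of methyl on an aromatic carbon, para to a large group, this assay shows a 1.3-fold lower number from compound 2 to compound 3 (0.10 log units; within the scatter) and so a third group joins the level already seen with fluoro and methyl. Between the two halogens the step is a 1.8-fold lower number from compound 1 to compound 3 (0.26 log units; within the scatter) and also stays inside the scatter, so no order can be drawn among the three compounds. At this position, three different single-atom groups therefore give numbers that cannot be set apart. Nothing at hand offers an explanation for this flat result.

As far as these compounds go, it remains open whether a different kind of group at this position, such as an amine, a carboxylic acid or a longer chain, would move the number beyond the scatter. The compounds shown also leave open whether a change elsewhere on the shared core would do so.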